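Changing the Ring on the Sulfonyl Sulfur

A few compounds are considered here, and "the series" means these few. Any claim that something is new, unique, unknown or untested is made for them only; others in the source may bear on it.

Of the compounds shown here, two have so far been measured in an assay on HEK293 cells for displacement of a labelled ligand from B1 bradykinin receptor (Homo sapiens), read by scintillation counting; a higher number here means a weaker inhibitor, a lower number a stronger inhibitor. Compound 1 `COc1cc(C)c(S(=O)(=O)N(C)CCOCC(=O)N2CCC(N3CCN(C(C)C)CC3)CC2)c(C)c1` gives 3.8 nM, and compound 2 `CN(Cc1ccc(C2=NCCN2)cc1)C(=O)COCCN(C)S(=O)(=O)c1c(Cl)cccc1Cl` gives 4.2 nM. Compound 2 carries the higher of the two numbers, but its nearest neighbour, compound 1, lies within the scatter, so the two cannot be told apart by this assay. Compound 3 `CN(Cc1ccc(C2=NCCN2)cc1)C(=O)COCCN(C)S(=O)(=O)c1ccc(OC(F)(F)F)cc1` has not yet been measured. It differs from compound 2 in one place: 4-(trifluoromethoxy)phenyl in place of 2,6-dichlorophenyl on a sulfonyl sulfur. Within the data shown here, no measured pair shows this change, so nothing in the data speaks for its effect. A moderate step from compound 2 to compound 3 in this assay is expected, a 2.1-fold higher number from compound 2 to compound 3 (0.33 log units; beyond the scatter), towards a higher number, though a result within the scatter would not surprise. The starting point is compound 2 because it gives 4.2 nM. Compound 3 is therefore estimated at 9 nM, with a range from 2.5 nM to 35 nM.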

Compound 3, inhibition constant: 85 nM
Beside the measured number, compound 3's estimate is 9.4-fold (0.98 log units) below it, and the stated range ends below it.
By their numbers in this assay, from the lowest: compounds 1 and 2 (each within the scatter of the next); then compound 3.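

On the sulfonyl sulfur, 4-(trifluoromethoxy)phenyl in place of 2,6-dichlorophenyl gives, in this assay, a 20-fold higher number from compound 2 to compound 3 (1.31 log units; beyond the scatter). Among these compounds, this is the first single-place step, and it shows that the position is not indifferent to the group it carries: both groups hold a six-membered aromatic ring of carbon only, yet the number moves by far more than the scatter. Nothing measured here accounts for the size of this step.

The change removes both chlorines and adds the trifluoromethoxy group at once, so the compounds shown do not separate the contribution of each. On these data alone, whether unsubstituted phenyl or a phenyl bearing a trifluoromethyl group would stay close to compound 2 or fall nearer compound 3 remains open.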